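Compound 3 to compound 4: tert-butyl for trifluoromethyl

The compounds below may be only part of what the source reports. "The series", "measured", "known", "first", "only" and "open" are said of these compounds alone.

Compound 3 (`Cc1cc(N[C@H](CCCCNCc2ccc(C(F)(F)F)cc2)C(=O)NO)cc(C)c1F`) gives > 5 ug/mL in a physicochemical assay for solubility, in phosphate buffer (a higher number here means a more soluble compound, a lower number a less soluble compound), which is a limit and not a number. Compound 1 (`Cc1cc(CNCCCC[C@@H](Nc2cc(C)c(F)c(C)c2)C(=O)NO)ccc1F`) gives > 5 ug/mL in this assay, again a limit. Compound 2 (`Cc1ccc(CNCCCC[C@@H](Nc2cc(C)c(F)c(C)c2)C(=O)NO)cc1`) gives > 5 ug/mL in this assay, also a limit. Among the compounds with values here, the series so far therefore offers a single reading: the limit of > 5 ug/mL in this assay, at which 3 of the 3 values shown sit.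

Compound 4 (`Cc1cc(N[C@H](CCCCNCc2ccc(C(C)(C)C)cc2)C(=O)NO)cc(C)c1F`) has tert-butyl in place of trifluoromethyl on an aromatic carbon, para to a large group: tert-butyl in place of trifluoromethyl on an aromatic carbon.

The closest measured change is at the same group, a step that the two limits leave unreadable from compound 2 to compound 3. Two further changes bear on the same aromatic end of the molecule: a step that the two limits leave unreadable from compound 1 to compound 2 and a step that the two limits leave unreadable from compound 1 to compound 3. None of the three has a readable size, so no step beyond the scatter is expected in this assay, and no direction can be assigned. The expected change is a step that the limit leaves unreadable from compound 3 to compound 4. A report of only a limit is the likeliest outcome. For compound 4 the estimated solubility is 7 ug/mL, with an expected range of 3 ug/mL to 20 ug/mL.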

Compound 4, solubility: > 5 ug/mL
Compound 4 was reported as a limit (the forecaster's own chance of this, stated with the estimate: 70%); the middle value is on the limit's open side.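

No new step can be read: compound 4 is reported as a limit, like compound 1, compound 2 and compound 3, so its steps to all three stay unreadable in this assay. The actual solubility of each compound, and any ordering among them, stays open: the limit of > 5 ug/mL in this assay, at which 4 of the 4 values shown sit.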